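The compounds below may be only part of what the source reports. "The series", "measured", "known", "first", "only" and "open" are said of these compounds alone.

Measured compounds in this study:

Compound 1, `CCCCCCCCCCCCCCCCCC(=O)N1CCOCC1`, gives 42.8 ug/mL.
Compound 2, `CCCCCCCC/C=C\CCCCCCCC(=O)N1CCCC1`, gives 5.2 ug/mL.
Compound 3, `CCCCCCCCCCCCCCCC(=O)N1CCCC1`, gives 4.6 ug/mL.

All three numbers come from a functional assay on MCF7 cells (Homo sapiens) for antiproliferative activity, read by sulforhodamine B assay, with a stated time of 48 h; on this read-out lower numbers stand for stronger inhibition of growth and higher numbers for weaker inhibition of growth. On that read-out compound 2 holds the second highest of the three values. Its nearest neighbour is compound 3, whose number is within the scatter of that of compound 2, so the two cannot be told apart. Its furthest neighbour is compound 1, whose number lies beyond the scatter and stands for weaker inhibition of growth than compound 2 shows.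

The piece now turns to compound 4, `CCCCCCCC/C=C\CCCCCCCC(=O)N1CCCCC1`, which has not been measured in this assay. Compound 4 differs from compound 2 in one place: piperidin-1-yl in place of pyrrolidin-1-yl on a carbonyl carbon. The long unsaturated chain and the carbonyl are kept; only the ring on the nitrogen is one atom larger.

Among the measured compounds shown here, no step between measured compounds touches this change, so nothing in the data tells the size or the direction of its effect. The expectation is therefore a step from compound 2 to compound 4 that is small or none beyond the scatter, written as a 1.1-fold higher number from compound 2 to compound 4 (0.02 log units; within the scatter). Compound 4 is thus estimated at 5.5 ug/mL in this assay, with a range from 2.5 ug/mL to 12 ug/mL.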

Compound 4, concentration for 50% growth inhibition: 7.6 ug/mL
Compound 4: the middle estimate sits 1.4-fold (0.14 log units) below what was measured; the measured number falls inside the stated range.
By their numbers in this assay, from the lowest: compounds 3, 2 and 4 (each within the scatter of the next); then compound 1.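

In this assay, among the compounds shown here, replacing pyrrolidin-1-yl with piperidin-1-yl on a carbonyl carbon gives the first readable step at this position, a 1.5-fold higher number from compound 2 to compound 4 (0.16 log units; within the scatter). With the long unsaturated chain and the carbonyl kept, the ring on the nitrogen can therefore hold one more carbon without any difference that can be told from the scatter, and compound 2 and compound 4 cannot be separated on this read-out. No supporting measurement bears on this result, so the data offer no explanation for it.

Since this replacement is shown on the unsaturated chain alone, it remains open whether piperidin-1-yl would match pyrrolidin-1-yl on the saturated chain of compound 3. Also open, as far as these compounds go, is how far this tolerance extends on the carbonyl carbon, for instance to a seven-membered azepan-1-yl ring, a 4-methylpiperazin-1-yl group carrying a second ring nitrogen, or an open-chain diethylamino group.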